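Amide Variation on a Shared Core

A few compounds are considered here, and "the series" means these few. Any claim that something is new, unique, unknown or untested is made for them only; others in the source may bear on it.

Measured compounds:
compound 1 `Nc1sc(-c2ccc(Br)cc2)c(-c2ccc(Cl)cc2)c1C(=O)NC1CCCCC1` gives 9590 nM
compound 2 `Nc1sc(-c2ccc(Br)cc2)c(-c2ccc(Cl)cc2)c1C(=O)N1CCCC1` gives 7460 nM

Both compounds were tested in a functional assay on A549 cells (Homo sapiens) for cytotoxicity, read by sulforhodamine B assay, with a stated time of 72 h; on this read-out higher numbers stand for weaker inhibition and lower numbers for stronger inhibition. Compound 2 carries the lowest of the numbers shown, but its only neighbour is compound 1, and the step of a 1.3-fold lower number from compound 1 to compound 2 (0.11 log units; within the scatter) lies within the scatter, so the two cannot be told apart on this read-out. What the data show is that exchanging one amide substituent for another at the carbonyl carbon left the number essentially unchanged.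

Compound 3 `Nc1sc(-c2ccc(Br)cc2)c(-c2ccc(Cl)cc2)c1C(=O)NCc1ccccc1` has not yet been measured. It differs from compound 2 in one place: benzylamino in place of pyrrolidin-1-yl on a carbonyl carbon. Among the measured compounds shown here, only one measured step bears on this change, the earlier exchange at the same carbonyl carbon, a 1.3-fold lower number from compound 1 to compound 2 (0.11 log units; within the scatter), which stayed within the scatter. On that basis the step to compound 3 is expected to be a 1.0-fold higher number from compound 2 to compound 3 (0.00 log units; within the scatter), that is, no movement beyond the scatter in this assay. Compound 3 is therefore estimated at 7500 nM, with a range from 3000 nM to 20000 nM.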

Compound 3, half-maximal inhibitory concentration: 18700 nM
Beside the measured number, compound 3's estimate is 2.5-fold (0.40 log units) below it, and the stated range covers the measured number.
By their numbers in this assay, from the lowest: compounds 2, 1 and 3 (each within the scatter of the next, the first and the last beyond it).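

In this assay the amide substituent on the carbonyl carbon proves not to be freely exchangeable: with benzylamino in place of pyrrolidin-1-yl there is a 2.5-fold higher number from compound 2 to compound 3 (0.40 log units; beyond the scatter), a modest step but the first here to clear the scatter. With benzyl in place of cyclohexyl on the amide-type nitrogen there is only a 1.9-fold higher number from compound 1 to compound 3 (0.29 log units; within the scatter), so the two compounds that keep the amide hydrogen cannot be told apart, and neither can compound 1 and compound 2, which means that the separation holds only between the two ends of this short series. No measurement offered here accounts for the step, and its origin remains unknown.

The compounds shown leave open how the number would respond to a morpholin-4-yl group, a terminal carboxylic acid or a longer chain such as phenylethyl on the amide nitrogen. They also leave open whether a methyl group on the benzylamino nitrogen, which would replace the amide hydrogen while keeping the benzyl ring, would stay with compound 3 or move towards compound 2.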